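The compounds below may be only part of what the source reports. "The series", "measured", "known", "first", "only" and "open" are said of these compounds alone.

In a functional assay on PC-3 cells (Homo sapiens), read by MTT assay, with a stated time of 48 h (a higher number here means a weaker inhibitor, a lower number a stronger inhibitor), compound 1 (`CCn1c(C(=O)NCCCN(C)C)ccc1C(CC)(CC)c1ccc(OCC(=O)C(C)(C)C)c(C)c1`) gives 1600 nM and compound 2 (`CCn1c(C(=O)NCCCN(C)C)ccc1C(CC)(CC)c1ccc(OCC(O)C(C)(C)C)c(C)c1`) gives 3100 nM, so the two stand within the scatter of each other. Compound 3 (`CC[C@@H](C)[C@H](NC(=O)c1ccc(C(CC)(CC)c2ccc(OCC(=O)C(C)(C)C)c(C)c2)n1CC)C(=O)O`) carries 1-carboxy-2-methylbutyl in place of 3-(dimethylamino)propyl on an amide-type nitrogen. Among the measured compounds shown here, the only measured step, a 1.9-fold higher number from compound 1 to compound 2 (0.29 log units; within the scatter), lies at another place, on a saturated chain carbon bound to an oxygen on an aromatic ring, and offers no direct guide to this change. A moderate rise is therefore expected only tentatively, with an expected step of a 3.8-fold higher number from compound 1 to compound 3 (0.57 log units; beyond the scatter). Compound 3 is estimated at 6000 nM, with an expected range of 1500 nM to 30000 nM.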

Compound 3, half-maximal inhibitory concentration: 1600 nM
The estimate for compound 3 lay 3.8-fold (0.57 log units) above the measured number, within the range that was stated.
By their numbers in this assay, from the lowest: compounds 1, 3 and 2 (each within the scatter of the next).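

In this assay, among the compounds shown here, the first reading at the amide-type nitrogen shows no change at the digits printed from compound 1 to compound 3 (within the scatter) when 1-carboxy-2-methylbutyl replaces 3-(dimethylamino)propyl. At this place, therefore, a chain bearing an amine and a chain bearing a carboxylic acid with 2 defined stereocentres give the same printed number. Nothing available explains this result.

As far as these compounds go, whether the methyl ester of that carboxylic acid or a simple 2-hydroxyethyl group would read alike remains open. The compounds shown also leave open how the opposite stereoisomers of 1-carboxy-2-methylbutyl would read.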